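Swapping Phenyl for Thiophene on a Sulfonate Ester

This account rests on a few compounds, and the source may have more. Where it says the series, first, only, none or still open, it means among the compounds named here.

Within the data shown here, compound 2 `O=C(c1ccc(Cl)c(C(F)(F)F)c1)N1CCC(n2cncc2-c2ccc(OS(=O)(=O)c3ccccc3)cc2)CC1` is the only compound here with a full number in an assay on HEK293 cells for antagonist activity at P2X purinoceptor 7 (Homo sapiens), read by fluorescence, with a stated time of 2 h; a lower number here means a stronger inhibitor, a higher number a weaker inhibitor: compound 2 gives 702 nM. Compound 1 `CC(=O)Oc1ccc(-c2cncn2C2CCN(C(=O)c3ccc(Cl)c(C(F)(F)F)c3)CC2)cc1` gives > 10000 nM in this assay, which is a limit of the assay rather than a number. Among the measured compounds shown here, the one measured step, an at least 14-fold lower number from compound 1 to compound 2 (1.15 log units; beyond the scatter), concerns the acetyl-to-phenylsulfonyl exchange and says nothing about the ring on the sulfonyl sulfur. Compound 3 `O=C(c1ccc(Cl)c(C(F)(F)F)c1)N1CCC(n2cncc2-c2ccc(OS(=O)(=O)c3cccs3)cc2)CC1` differs from compound 2 by thiophen-2-yl in place of phenyl on a sulfonyl sulfur. For the measured compounds named here, no measured step bears on this change, so in this assay no step beyond the scatter is expected. Compound 3 is therefore estimated at 700 nM, between 250 nM and 2000 nM. The expected step, a 1.0-fold lower number from compound 2 to compound 3 (0.00 log units; within the scatter), stays within the scatter.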

Compound 3, half-maximal inhibitory concentration: 238 nM
Beside the measured number, compound 3's estimate is 2.9-fold (0.47 log units) above it; the whole stated range lies above it.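

Thiophen-2-yl in place of phenyl on a sulfonyl sulfur gives a 2.9-fold lower number from compound 2 to compound 3 (0.47 log units; beyond the scatter) in this assay and so shows that the ring on the sulfur itself counts, which the acetyl exchange could not show. Set against acetyl, (thiophen-2-yl)sulfonyl gives an at least 42-fold lower number from compound 1 to compound 3 (1.62 log units; beyond the scatter) and this size is only a lower bound. Compound 1 stands at a limit of the assay and not at a number: the limit of > 10000 nM in this assay, at which 1 of the 3 values shown sits. Going by these compounds, how a furan or pyridine ring on the sulfonyl sulfur would compare stays open, as does a plain methyl on that sulfur.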